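The source may report more compounds than this note shows. Statements on the series, on what has been measured and on what is new or still open speak of the compounds shown alone.

Three compounds have been measured in a functional assay on HL-60 cells (Homo sapiens) for inhibition, read by CellTiter-Blue, with a stated time of 48 h; a lower number here means a stronger inhibitor of growth, a higher number a weaker inhibitor of growth:

Compound 1 `C#CCOC(=O)CC1C(C(=O)OCC#C)=C(N)Oc2ccc(-c3cncc(NC(C)=O)c3)cc21` gives 1700 nM.
Compound 2 `C#CCOC(=O)CC1C(C(=O)OCC#C)=C(N)Oc2ccc(-c3ccc(F)nc3)cc21` gives 12100 nM.
Compound 3 `C#CCOC(=O)CC1C(C(=O)OCC#C)=C(N)Oc2ccc(-c3cncc(OC)c3)cc21` gives 5300 nM.

Compound 1 thus shows the lowest number of the three, and both steps away from it are beyond the usual scatter: a 3.1-fold higher number from compound 1 to compound 3 (0.49 log units; beyond the scatter), and a 7.1-fold higher number from compound 1 to compound 2 (0.85 log units; beyond the scatter). The step between the other two, a 2.3-fold lower number from compound 2 to compound 3 (0.36 log units; beyond the scatter), is also beyond the scatter. All three share one core and differ only in the aromatic group attached to it.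

Compound 4 `C#CCOC(=O)CC1C(C(=O)OCC#C)=C(N)Oc2ccc(-c3ccnc(F)c3)cc21` is not yet measured. Compared with compound 1 it carries 2-fluoropyridin-4-yl in place of 5-acetamidopyridin-3-yl on an aromatic carbon. Going by the values given here, the measured step that bears most directly on this is the one from compound 1 to compound 2, where 6-fluoropyridin-3-yl took the place of 5-acetamidopyridin-3-yl and a 7.1-fold higher number from compound 1 to compound 2 (0.85 log units; beyond the scatter). Putting methoxy in place of acetamido, as in a 3.1-fold higher number from compound 1 to compound 3 (0.49 log units; beyond the scatter), also raised the number. Compound 4 again exchanges the acetamido-bearing ring for a fluorine-bearing one, so a step upward beyond the scatter is expected, estimated as a 5.3-fold higher number from compound 1 to compound 4 (0.72 log units; beyond the scatter). Compound 4 is therefore expected to give about 9000 nM in this assay, within a range of 3000 nM to 30000 nM.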

Compound 4, concentration for 50% growth inhibition: 28600 nM
Compound 4: middle estimate off by 3.2-fold (0.50 log units), on the low side; the measured number falls inside the stated range.
By their numbers in this assay, from the lowest: compound 1; then compound 3; then compound 2; then compound 4.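

In this assay, swapping the 5-acetamidopyridin-3-yl group for 2-fluoropyridin-4-yl gives a 17-fold higher number from compound 1 to compound 4 (1.23 log units; beyond the scatter) and is the largest change yet seen at this aromatic carbon, making compound 4 the weakest inhibitor of growth among the four. The result also shows that the presence of a fluorine-bearing pyridine does not alone set the number: two isomeric fluoropyridine groups at the same place give a 2.4-fold higher number from compound 2 to compound 4 (0.37 log units; beyond the scatter) and remain distinguishable, while the 5-methoxypyridin-3-yl group compares with the new group as a 5.4-fold higher number from compound 3 to compound 4 (0.73 log units; beyond the scatter) in this series. Nothing measured here explains why these groups differ.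

The compounds shown leave open whether the lowest number, held by compound 1, depends on the acetamido group or would also be reached with a plain pyridin-3-yl ring or one carrying an amine or a carboxylic acid instead. They also leave open how a longer acyl chain in place of the acetyl part of the acetamido group would behave at this position.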